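From chloro to fluoro on a shared core

The compounds below may be only part of what the source reports. "The series", "measured", "known", "first", "only" and "open" are said of these compounds alone.

Measured so far in a functional assay on HeLa cells (Homo sapiens) for antiproliferative activity, read by MTT assay, with a stated time of 48 h; a lower number here means a stronger inhibitor, a higher number a weaker inhibitor:
- compound 1 `O=[N+]([O-])c1cccc(-c2nn(-c3ccccc3)cc2C(Nc2nc3ccccc3s2)c2c(O)ccc3ccccc23)c1`: 8220 nM
- compound 2 `Cc1ccc2nc(NC(c3cn(-c4ccccc4)nc3-c3cccc(Cl)c3)c3c(O)ccc4ccccc34)sc2c1`: 9430 nM
- compound 3 `COc1ccc2nc(NC(c3cn(-c4ccccc4)nc3-c3ccc(Cl)cc3)c3c(O)ccc4ccccc34)sc2c1`: 5200 nM

Compound 3 (5200 nM) sits within the usual scatter of both other compounds, so the three cannot be ranked. Compound 4 `COc1ccc2nc(NC(c3cn(-c4ccccc4)nc3-c3ccc(F)cc3)c3c(O)ccc4ccccc34)sc2c1` is still unmeasured. It carries one change from compound 3 (fluoro in place of chloro on an aromatic carbon): fluoro in place of chloro on an aromatic carbon. For the measured compounds named here, no measured pair differs in one place only, so the data offer no direct guide to this swap. Compound 1 (8220 nM) and compound 2 (9430 nM) differ from compound 3 in several places, yet both stay within the scatter of it. The expected result in this assay is therefore no step beyond the scatter (a 1.2-fold higher number from compound 3 to compound 4 (0.06 log units; within the scatter)). Compound 4 is estimated at 6000 nM (expected range 2500 nM to 14000 nM).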

Compound 4, half-maximal inhibitory concentration: 4630 nM
For compound 4 the middle estimate is 1.3-fold (0.11 log units) above the measured one; the measured number falls inside the stated range.
By their numbers in this assay, from the lowest: compounds 4, 3, 1 and 2 (each within the scatter of the next, the first and the last beyond it).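

For the compounds shown here, compound 3 and compound 4 are the first pair here that differ in one place only, so the change from 4-chlorophenyl to 4-fluorophenyl can be read directly in this assay, which gives a 1.1-fold lower number from compound 3 to compound 4 (0.05 log units; within the scatter) and so does not separate the two groups. At this position, para to a large group, either halogen fits the same result. No measurement shown bears on the reason for this.

From the compounds shown here alone, whether an amine, a carboxylic acid or a longer chain at this position would give a step beyond the scatter remains open.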